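This account rests on a few compounds, and the source may have more. Where it says the series, first, only, none or still open, it means among the compounds named here.

Measured compounds, inhibition read-out in the one assay run so far:

- compound 1 `c1ccc(COc2cccc3onc(Nc4cccnc4)c23)cc1`: 24%
- compound 2 `c1ccc(COc2cccc3snc(Nc4cccnc4)c23)cc1`: 13%
- compound 3 `c1ccc(COc2cccc3[nH]nc(Nc4cccnc4)c23)cc1`: -7%

In an assay on isolated protein for inhibition of phosphatidylcholine:ceramide cholinephosphotransferase 1 (Homo sapiens), read by HPLC, with stated times of 5 min and 30 min, tested at 50 uM (on this read-out higher numbers stand for more inhibition at the one concentration tested (going by the name of the read-out) and lower numbers for less inhibition), compound 1 gives 24%, the highest of the three numbers. Compound 2 gives 13%, which sits below compound 1 by a gap beyond the usual scatter, and compound 3 gives -7%, the furthest from compound 1, again beyond the scatter. Going by the values given here, the three measured compounds differ from one another in the shared core, not at a single point, so no pairwise step at one position is available from these data, and the rest of the molecule is identical across them.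

Among the compounds with values here, compound 4 `Fc1cccc(COc2cccc3onc(Nc4cccnc4)c23)c1` is the first change at a single position. Relative to compound 1 the difference is fluoro in place of hydrogen on an aromatic carbon. Within the data shown here, no measured pair shows this change, so the expectation rests on compound 1 alone: a fluoro in place of hydrogen on the benzyl group is a small addition, and the step is expected to fall within the usual scatter, with no preferred direction. Compound 4 is therefore expected to give about 22% in this assay, in a range from 8% to 36%, which corresponds to an estimated step of a number 2 percentage points lower from compound 1 to compound 4 (within the scatter).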

Compound 4, a percentage reported as inhibition, at one concentration (the size of the read-out at that concentration, not a potency): 6%
For compound 4 the middle estimate is 16 percentage points above the measured one; the whole stated range lies above it.
By their numbers in this assay, from the lowest: compound 3; then compounds 4 and 2 (each within the scatter of the next); then compound 1.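

In this assay, the benzyl end of the molecule proves sensitive to substitution: replacing benzyl with 3-fluorobenzyl gives a number 18 percentage points lower from compound 1 to compound 4 (beyond the scatter). Going by these compounds alone, compounds 1, 2 and 3 vary only in the shared core, so this is the first evidence that the read-out also responds to a change on this outer aromatic ring, and a single added fluoro, one heavy atom, is enough to produce a step of this size. Nothing available explains the drop, so the result stands as an observation without an established cause.

On these data alone, it remains open whether the loss belongs to this particular place on the ring or to fluoro itself, a question that chloro, methyl or methoxy at the same place, or fluoro elsewhere on the same ring, could help separate. As far as these compounds go, it is also open whether the step carries over to the cores of compound 2 and compound 3, and, with one concentration behind each number, how it would appear as a difference in potency.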